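Swapping the Sulfonate Oxygen for a Methylene Link

The source may report more compounds than this note shows. Statements on the series, on what has been measured and on what is new or still open speak of the compounds shown alone.

Of the compounds shown here, two have been measured in a functional assay on HEK293S cells with Glucose-dependent insulinotropic receptor (Homo sapiens) as the target, read by HTRF and cAMP accumulation, with a stated time of 45 min; on this read-out lower numbers stand for smaller maximal responses and higher numbers for larger maximal responses.
Compound 1 `C[C@@H]1CN(c2nnc(C(F)(F)F)o2)CCN1c1ncc(OCc2ccc(OS(C)(=O)=O)cc2F)cn1` gives 156%.
Compound 2 `C[C@@H]1CN(C(=O)OC2(C(F)(F)F)COC2)CCN1c1ncc(OCc2ccc(OS(C)(=O)=O)cc2F)cn1` gives 141%.

Compound 2 stands at the lower of the two numbers. For the measured compounds named here, the only measured step, a number 15 percentage points lower from compound 1 to compound 2 (beyond the scatter), comes from exchanging the group on the ring nitrogen. Compound 3 `C[C@@H]1CN(C(=O)OC2(C(F)(F)F)COC2)CCN1c1ncc(OCc2ccc(CS(C)(=O)=O)cc2F)cn1` keeps that part of compound 2 unchanged and alters the far end of the molecule instead: (methylsulfonyl)methyl in place of (methylsulfonyl)oxy on an aromatic carbon. Going by the values given here, no measured step touches this end, so the single known step in this assay gives no guide to the size or direction of the new change. With nothing to point either way, the most cautious expectation is a change no larger than the usual scatter. Compound 3 is therefore estimated to give 140%, with a range from 115% to 165%. This amounts to an expected step of a number 1 percentage points lower from compound 2 to compound 3 (within the scatter).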

Compound 3, intrinsic activity: the largest response reached, in percent of the reference agonist's in the Glucose-dependent insulinotropic receptor assay: 91%
Beside the measured number, compound 3's estimate is 49 percentage points above it, outside the stated range (below it).
By their numbers in the Glucose-dependent insulinotropic receptor assay, from the lowest: compound 3; then compound 2; then compound 1.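

In the Glucose-dependent insulinotropic receptor assay, this end of the molecule proves far from silent: a number 50 percentage points lower from compound 2 to compound 3 (beyond the scatter) follows from exchanging (methylsulfonyl)oxy for (methylsulfonyl)methyl, although the two groups have the same number of heavy atoms. In a physicochemical assay for lipophilicity, in phosphate buffer, at pH 7.4 (a lower number here means a more polar compound, a higher number a more lipophilic compound), compound 2 gives 3.7 and compound 3 gives 2.9, so this exchange changes more than the maximal response. On this scale, compound 3 is the more polar of the pair: the measured distribution coefficient of compound 2, 3.7, and of compound 3, 2.9, a number 0.80 log units lower (beyond the scatter)

A single pair cannot show whether the smaller maximal response is tied to the lower lipophilicity or to some other result of replacing the oxygen link. It also leaves open how a simple methylsulfonyl group or a sulfonamide on the same aromatic carbon would behave, and whether the step would be similar with the 5-(trifluoromethyl)-1,3,4-oxadiazol-2-yl group of compound 1.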